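Chloro in place of fluoro: compound 1 to compound 4

A few compounds are considered here, and "the series" means these few. Any claim that something is new, unique, unknown or untested is made for them only; others in the source may bear on it.

Measured in an ADME assay on NIH3T3 cells (Mus musculus) for cytotoxicity, read by LDH release, with a stated time of 48 h; on this read-out lower numbers stand for stronger inhibition and higher numbers for weaker inhibition:
- compound 1 `O=C(COc1c(F)cc(C(=O)c2ccc(F)cc2)cc1Cl)NNC(=O)c1ccc(=O)oc1`: 89800 nM
- compound 2 `Cn1cnc(C(=O)NNC(=O)COc2ccc(C(=O)c3ccccc3)cc2)c1`: 97400 nM
- compound 3 `Cn1cnc(C(=O)NNC(=O)COc2c(F)cc(C(=O)c3ccc(F)cc3)cc2Cl)c1`: 94400 nM

The three values lie within the usual scatter of one another, so compound 1 cannot be ranked against the other two. The next compound to be read, compound 4 `O=C(COc1c(F)cc(C(=O)c2ccc(Cl)cc2)cc1Cl)NNC(=O)c1ccc(=O)oc1`, keeps the core of compound 1 and alters one group: chloro in place of fluoro on an aromatic carbon. This is chloro in place of fluoro on an aromatic carbon, turning 4-fluorophenyl into 4-chlorophenyl, para to a large group.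

Within the data shown here, only one measured step changes a single place, a 1.1-fold higher number from compound 1 to compound 3 (0.02 log units; within the scatter). It concerns a group on a carbonyl carbon, not the halogen in question, so it bears on compound 4 only indirectly. Among the measured compounds shown here, no measured step covers the fluoro to chloro change itself, and three compounds make a thin basis. Even so, the one step available is small, and no step beyond the scatter is expected in this assay. The expected step is a 1.1-fold lower number from compound 1 to compound 4 (0.02 log units; within the scatter). Compound 4 is estimated at 85000 nM, with an expected range from 50000 nM to 125000 nM.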

Compound 4, half-maximal inhibitory concentration: 78600 nM
Compound 4: middle estimate off by 1.1-fold (0.03 log units), on the high side; low and high end bracket the measured number.
By their numbers in this assay, from the lowest: compounds 4, 1, 3 and 2 (each within the scatter of the next).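

In this assay, among these compounds, the exchange of 4-fluorophenyl for 4-chlorophenyl gives a 1.1-fold lower number from compound 1 to compound 4 (0.06 log units; within the scatter) and so provides the first direct reading at this position, on an aromatic carbon para to a large group. Within this pair, fluoro and chloro cannot be separated on this read-out. Alongside a 1.1-fold higher number from compound 1 to compound 3 (0.02 log units; within the scatter) at the carbonyl carbon, the series now has single-place changes at two different sites of the core of compound 1, and neither step lies beyond the scatter. No measured property bears on the halogen exchange, so the step comes with no explanation.

The halogen pair leaves open whether a different kind of group at the same position, such as an amine, a carboxylic acid or a longer alkyl chain, would give a step beyond the scatter. Also open, on these data alone, is whether the same exchange of fluoro for chloro, made on compound 3 with its methylimidazole-bearing end, would give a step of similar size.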